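Removing the aryl group from a triazole-bearing butenolide

The source may report more compounds than this note shows. Statements on the series, on what has been measured and on what is new or still open speak of the compounds shown alone.

compound 1, `COc1ccccc1-c1cn(C[C@H](O)[C@H]2OC(=O)C(OCc3ccccc3)=C2OCc2ccccc2)nn1`: > 100000 nM
compound 2, `O=C1O/C(=C\Cn2cc(-c3cccc(O)c3)nn2)C(OCc2ccccc2)=C1OCc1ccccc1`: 33700 nM

Of the compounds shown here, two sharing the butenolide core have been measured in a functional assay on CFPAC-1 cells (Homo sapiens) for antiproliferative activity, read by MTT assay, with a stated time of 72 h; on this read-out lower numbers stand for stronger inhibition and higher numbers for weaker inhibition. Compound 1 gives only a limit of the assay, > 100000 nM. Compound 2, which carries a different side chain, gives a number in this assay, 33700 nM. Among the measured compounds shown here, no step between these two is counted, so their values are simply reported side by side, with compound 1 sitting at the limit of > 100000 nM in this assay, at which 1 of the 2 values shown sits.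

Compound 3, `O=C1O[C@H]([C@@H](O)Cn2ccnn2)C(OCc2ccccc2)=C1OCc1ccccc1`, has not yet been measured. It differs from compound 1 by hydrogen in place of 2-methoxyphenyl on an aromatic carbon. For the measured compounds named here, with compound 1 at a limit, no measured step is available to anchor this change, and the expectation is therefore no movement beyond the scatter; the step that the limit leaves unreadable from compound 1 to compound 3 is an estimate only. Compound 3 is expected to give about 120000 nM, with a range from 40000 nM to 350000 nM, most likely reported again as a limit.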

Compound 3, half-maximal inhibitory concentration: > 100000 nM
Compound 3 ended at the assay's limit (the forecaster's own chance of this, stated with the estimate: 70%); the middle value is on the limit's open side.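

Among the compounds shown here, compound 1 and compound 3 both end at a limit in this assay, so no step between them can be read: the limit of > 100000 nM in this assay, at which 2 of the 3 values shown sit.

The compounds shown leave open what hydrogen in place of 2-methoxyphenyl on an aromatic carbon does to antiproliferative activity.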